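This account rests on a few compounds, and the source may have more. Where it says the series, first, only, none or still open, it means among the compounds named here.

Measured so far in an assay on CHO cells for displacement of a labelled ligand from prostaglandin E2 receptor EP3 subtype (Homo sapiens), read by radioligand binding; on this read-out higher numbers stand for weaker inhibition and lower numbers for stronger inhibition:

- compound 1, `CCC(CC)(c1nnc[nH]1)c1ccc(-c2ccc3cccc(F)c3c2)[nH]c1=O`; compound 1 gives 19 nM
- compound 2, `Cc1nc(C(c2ccc(-c3ccc4cccc(F)c4c3)[nH]c2=O)C(C)C)[nH]c1C`; compound 2 gives 7 nM

Compound 2 stands at the lowest number of the two. Its nearest neighbour is compound 1, whose number is higher by a gap that lies beyond the scatter of repeated measurements, so compound 2 is the stronger inhibitor of this pair on this assay. The two differ at more than one place, so no single change can be read from them.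

Compound 3, `CC(C)C(/C=C1\CCNC1=O)c1ccc(-c2ccc3cccc(F)c3c2)[nH]c1=O`, has not yet been measured. It differs from compound 2 by one change: a group of 7 heavy atoms (5 carbon, 1 nitrogen, 1 oxygen; one five-membered non-aromatic ring with 1 hetero atom) in place of a group of 7 heavy atoms (5 carbon, 2 nitrogen; one five-membered aromatic ring with 2 hetero atoms), on a saturated chain carbon bound to an aromatic carbon and a saturated chain carbon. Going by the values given here, no step between measured compounds carries this change, so the expectation rests on the shared core and on the value of compound 2 alone, with no pair of measured values to anchor the direction.

The step from compound 2 to compound 3 in this assay is expected to be a modest move toward a higher number, a 2.9-fold higher number from compound 2 to compound 3 (0.46 log units; beyond the scatter), somewhat beyond the scatter. For compound 3 in this assay the estimate is 20 nM, within a range from 6 nM to 70 nM.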

Compound 3, inhibition constant: 2.2 nM
Compound 3: middle estimate off by 9.1-fold (0.96 log units), on the high side, and the stated range ends above it.
By their numbers in this assay, from the lowest: compound 3; then compound 2; then compound 1.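

In this assay, the place on a saturated chain carbon bound to an aromatic carbon and a saturated chain carbon does not need an aromatic ring to keep a low number: exchanging 4,5-dimethyl-1H-imidazol-2-yl for the five-membered non-aromatic ring group gives a 3.2-fold lower number from compound 2 to compound 3 (0.50 log units; beyond the scatter). The two groups match in heavy-atom, hydrogen-bond donor and hydrogen-bond acceptor counts and in having no net charge, so these counts alone do not fix the value at this place. No measurement here bears on what lies behind this step.

Going by these compounds, it remains open whether the double bond outside the aromatic rings matters, as a single change at that bond alone would be needed to separate it from the ring exchange. On these data alone, it is equally open how far this place tolerates other groups, such as an open-chain amide, a primary amine or a carboxylic acid, and whether the same exchange would give a step of similar size on the differently substituted chain carbon of compound 1.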